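A shorter nitrooxyalkyl ester chain on compound 3

The compounds below may be only part of what the source reports. "The series", "measured", "known", "first", "only" and "open" are said of these compounds alone.

For the measured compounds named here, compound 3 `COc1cc(/C=C/C(=O)OCCCCCO[N+](=O)[O-])ccc1O` stands at the high end of the two numbers known in a functional assay on NCI-H460 cells (Homo sapiens) for cytotoxicity, read by resazurin assay, with a stated time of 72 h (on this read-out lower numbers stand for stronger inhibition and higher numbers for weaker inhibition), where compound 3 gives 12300 nM. Compound 2 `COc1cc(/C=C/C(=O)OC/C=C/CO[N+](=O)[O-])ccc1O` gives 4980 nM in this assay, a lower number that lies beyond the scatter. Compound 1 `COc1cc(/C=C/C(=O)OCCCCCO[N+](=O)[O-])ccc1OCCCCCO[N+](=O)[O-]` returns only a limit in this assay, > 50000 nM, and no number. Going by the values given here, the one step that can be sized is an at least 4.0-fold lower number from compound 1 to compound 3 (0.60 log units; beyond the scatter), a change of hydrogen in place of 5-(nitrooxy)pentyl on an oxygen on an aromatic ring; it touches the limit of > 50000 nM in this assay, at which 1 of the 3 values shown sits, and so is a lower bound on its true size.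

Compound 4 `COc1cc(/C=C/C(=O)OCCCO[N+](=O)[O-])ccc1O` differs from compound 3 by nitrooxy in place of 2-(nitrooxy)ethyl on a saturated chain carbon, three bonds along the chain from an oxygen next to a carbonyl group. Among the compounds with values here, none of the measured steps alters the length of the ester chain, so the step from compound 1 to compound 3 gives no direct guide, and the pair of compound 2 and compound 3 shows only that two different chains give numbers beyond the scatter of each other. He therefore expects no step beyond the scatter, a 1.2-fold lower number from compound 3 to compound 4 (0.09 log units; within the scatter). For compound 4 in this assay he estimates 10000 nM, within a range from 4000 nM to 30000 nM.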

Compound 4, half-maximal inhibitory concentration: 29000 nM
Estimate against measurement, compound 4: 2.9-fold (0.46 log units) below; the measured number falls inside the stated range.
By their numbers in this assay, from the lowest: compound 2; then compound 3; then compound 4. At a limit, above all of these: compound 1.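

The ester chain proves to be a place where the read-out responds to length: in this assay, nitrooxy in place of 2-(nitrooxy)ethyl gives a 2.4-fold higher number from compound 3 to compound 4 (0.37 log units; beyond the scatter), so the shorter saturated chain comes with weaker inhibition. The span at this place is wider still against the chain of compound 2, with a 5.8-fold higher number from compound 2 to compound 4 (0.77 log units; beyond the scatter), and this shows that the ester chain alone can move the number beyond the scatter while the rest of the structure stays fixed. Nothing given here accounts for the direction or size of either step.

The compounds shown leave open whether a longer chain than that of compound 3 would lower the number further or raise it. They also leave open how a chain ending in an amine or a hydroxyl group, in place of nitrooxy, would read.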